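Replacing tert-butyl with pentyl: what to expect

The source may report more compounds than this note shows. Statements on the series, on what has been measured and on what is new or still open speak of the compounds shown alone.

Measured so far in a functional assay on the whole organism with Scenedesmus acutus as the target, with a stated time of 20 h (on this read-out lower numbers stand for stronger inhibition and higher numbers for weaker inhibition), are two compounds:
Compound 1 `CCOC(=O)c1cc(N2C(=O)C3=C(CCCC3)C2=O)ccc1Cl` gives 2140 nM as a number
Compound 2 `CC(C)(C)OC(=O)c1cc(N2C(=O)C3=C(CCCC3)C2=O)ccc1Cl` gives > 100000 nM as a limit

Compound 2 stands at the limit of > 100000 nM in this assay, at which 1 of the 2 values shown sits, and so has a limit and no number. The change to compound 3 `CCCCCOC(=O)c1cc(N2C(=O)C3=C(CCCC3)C2=O)ccc1Cl` puts pentyl in place of tert-butyl on an oxygen next to a carbonyl group while the shared core stays the same. Going by the values given here, one measured step bears on this change, at the same place. That step is an at least 46-fold higher number from compound 1 to compound 2 (1.66 log units; beyond the scatter) and it is large, with tert-butyl in place of ethyl. Compound 3 lacks tert-butyl, as does compound 1 at 2140 nM in this assay, so a large move to a lower number is expected. Pentyl is not ethyl, however, and no pentyl compound has been measured, so the range stays wide. The expected change is an at least 20-fold lower number from compound 2 to compound 3 (1.30 log units; beyond the scatter) and it points to stronger inhibition. Compound 3 is estimated at 5000 nM with an expected range from 800 nM to 40000 nM in this read-out.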

Compound 3, half-maximal inhibitory concentration: 5370 nM
Estimate against measurement, compound 3: 1.1-fold (0.03 log units) below, within the range that was stated.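

In this assay, pentyl in place of tert-butyl on an oxygen next to a carbonyl group gives an at least 18-fold lower number from compound 2 to compound 3 (1.27 log units; beyond the scatter), so among these compounds the result does not follow the carbon count alone: pentyl has more carbon atoms than tert-butyl, yet compound 3 returns to a measurable number. The longer straight chain is not free of cost, since propyl in place of hydrogen on a saturated chain carbon, two bonds along the chain from an oxygen next to a carbonyl group, gives a 2.5-fold higher number from compound 1 to compound 3 (0.40 log units; beyond the scatter), a modest step beside the large one to pentyl. Compound 2 has a limit and no number, so the true size of its steps stays unknown: the limit of > 100000 nM in this assay, at which 1 of the 3 values shown sits.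

From the compounds shown here alone, whether a still longer chain such as octyl moves the number further, or whether the modest trend from ethyl to pentyl holds for propyl and butyl in between, stays open. Also open, going by these compounds, is how a branched group smaller than tert-butyl, such as isopropyl, or a free carboxylic acid at this place would read.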